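From a pentenyl carbonyl to an isopropyl carbonyl

The source may report more compounds than this note shows. Statements on the series, on what has been measured and on what is new or still open speak of the compounds shown alone.

Compound 1 `CCC/C=C/C(=O)N(Cc1ccc(OC)c(O)c1)c1cc(OC)c(OC)c(OC)c1`: 57 nM
Compound 2 `COc1ccc(CNc2cc(OC)c(OC)c(OC)c2)cc1Br`: 39800 nM
Compound 3 `COc1cc(NCc2ccc(Br)cc2)cc(OC)c1OC`: > 80000 nM

The three measured compounds were tested in a functional assay on KYSE-450 cells (Homo sapiens) for inhibition, read by MTT assay, with a stated time of 48 h; a lower number here means a stronger inhibitor, a higher number a weaker inhibitor. Compound 1 holds the lower of the two numbers given, and compound 2 lies far above it, a gap well beyond the scatter. Compound 3 is reported only as a limit of the assay, (the limit of > 80000 nM in this assay, at which 1 of the 3 values shown sits). Both compound 2 and compound 3 carry a plain secondary amine in place of the amide of compound 1, and both sit at the weak end of the set.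

The unmeasured compound 4 `COc1ccc(CN(C(=O)C(C)C)c2cc(OC)c(OC)c(OC)c2)cc1O` keeps the core of compound 1 and alters only the acyl group: isopropyl in place of pent-1-en-1-yl on a carbonyl carbon. The change removes the double bond of the pent-1-en-1-yl and shortens the chain to isopropyl. Among the compounds with values here, no measured pair shows this step, so the expectation rests on compound 1 alone. A modest loss is expected for compound 4, a 3.5-fold higher number from compound 1 to compound 4 (0.55 log units; beyond the scatter). Compound 4 is estimated at 200 nM, within 50 nM to 1500 nM.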

Compound 4, half-maximal inhibitory concentration: 390 nM
Estimate against measurement, compound 4: 2.0-fold (0.29 log units) below; measured number inside the range.
By their numbers in this assay, from the lowest: compound 1; then compound 4; then compound 2. At a limit, above all of these: compound 3.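

In this assay, isopropyl in place of pent-1-en-1-yl on a carbonyl carbon gives a 6.8-fold higher number from compound 1 to compound 4 (0.84 log units; beyond the scatter), a modest step but one beyond the scatter. Within the data shown here, this is the first step read at this position, and it shows that the number responds to the acyl group, while compound 4, with the shorter chain and no double bond, still gives 390 nM. The data shown offer no measured reason for this step.

The double bond and the chain length change together in this one step, and the compounds shown do not separate the two. On these data alone, how a pentyl chain on the same carbonyl carbon, which would keep the length without the double bond, or a cyclopropyl group would stand remains open.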